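A few compounds are considered here, and "the series" means these few. Any claim that something is new, unique, unknown or untested is made for them only; others in the source may bear on it.

Compound 1 `COc1ccc(-c2cc(-c3ccc(S(=O)(=O)NC4CC4)cc3)cnc2N)cn1` carries a cyclopropylsulfamoyl group on an aromatic carbon of a six-membered aromatic ring of carbon only. For the measured compounds named here, in a physicochemical assay for lipophilicity, at pH 7.4 (on this read-out lower numbers stand for lower lipophilicity and higher numbers for higher lipophilicity), compound 1 gives 2.7, the higher of the two numbers measured so far. Compound 2 `COc1ccc(-c2cc(-c3cccc(C(N)=O)c3)cnc2N)cn1`, which bears a carbamoyl group instead, gives 1.7 in this assay, and the gap between these two values lies beyond the usual scatter. Compound 3 `COc1ccc(-c2cc(-c3ccc(C(=O)N(C)C)cc3)cnc2N)cn1` has not been measured yet. It differs from compound 1 in one place: dimethylcarbamoyl in place of cyclopropylsulfamoyl on an aromatic carbon. Going by the values given here, no measured pair shows this exact change, so its size can only be judged from what the two measured compounds show. Compound 3 is expected to fall below compound 1 because compound 2 also carries a carbamoyl-type group and gives 1.7. The fall is expected to be moderate, a step of a number 0.50 log units lower from compound 1 to compound 3 (beyond the scatter). For compound 3 the estimated value is 2.2, with a likely range from 1.7 to 2.7.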

Compound 3, distribution coefficient: 2.1
Estimate against measurement, compound 3: 0.10 log units above, and the stated range covers the measured number.
By their numbers in this assay, from the lowest: compound 2; then compound 3; then compound 1.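

In this assay this position proves sensitive to the group it carries: on the aromatic carbon para to a large group, dimethylcarbamoyl in place of cyclopropylsulfamoyl gives a number 0.60 log units lower from compound 1 to compound 3 (beyond the scatter) with the rest of the molecule unchanged. This single change removes the three-membered ring and the hydrogen-bond donor and reduces the group from 7 heavy atoms to 5, so one step cannot show which of these differences matters. No supporting measurement here accounts for the size of the step.

Still open, going by these compounds, is how an amine, a carboxylic acid or a longer chain at this same place would compare with these two groups. A cyclopropylcarbamoyl group would also keep the ring while replacing the sulfonyl part, which could begin to separate those differences.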